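Swapping Phenyl for Benzyl on the Ring Nitrogen

A few compounds are considered here, and "the series" means these few. Any claim that something is new, unique, unknown or untested is made for them only; others in the source may bear on it.

Three measured compounds share one core and differ only in the group on an aromatic nitrogen. Compound 1 `Cc1cc(NC(=O)Cn2nnc(-c3ccccc3)n2)n(C2CCCCC2)n1` carries a cyclohexyl there; in an assay on HEK293 cells for activation of Kir3.1/Kir3.2 (Homo sapiens), read by thallium flux (a lower number here means a smaller maximal response, a higher number a larger maximal response), compound 1 gives 92%. Compound 2 `Cc1cc(NC(=O)Cn2nnc(-c3ccccc3)n2)n(CC2CCCCC2)n1` carries a cyclohexylmethyl, and in this assay compound 2 gives 77%. Compound 3 `Cc1cc(NC(=O)Cn2nnc(-c3ccccc3)n2)n(-c2ccccc2)n1` carries a phenyl, and in this assay compound 3 gives 66%, the lowest of the three numbers. Each step among them is modest yet beyond the scatter: a number 15 percentage points lower from compound 1 to compound 2 (beyond the scatter), a number 26 percentage points lower from compound 1 to compound 3 (beyond the scatter) and a number 11 percentage points lower from compound 2 to compound 3 (beyond the scatter).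

Compound 4 `Cc1cc(NC(=O)Cn2nnc(-c3ccccc3)n2)n(Cc2ccccc2)n1` has not yet been measured. It differs from compound 3 in one place: benzyl in place of phenyl on an aromatic nitrogen. The most relevant guide is the pair of compound 1 and compound 2, where cyclohexylmethyl took the place of cyclohexyl, a change of the same kind, and the response fell: a number 15 percentage points lower from compound 1 to compound 2 (beyond the scatter). The ring that remains aromatic has so far gone with the lower number, as the step of a number 11 percentage points lower from compound 2 to compound 3 (beyond the scatter) shows. Taken together, a further modest drop is expected, roughly a number 11 percentage points lower from compound 3 to compound 4 (beyond the scatter), though with only one comparable step the uncertainty is wide. Compound 4 is therefore estimated at 55%, most likely between 35% and 78%.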

Compound 4, largest response reached (Emax), in percent of the reference or control that the assay uses: 74%
Beside the measured number, compound 4's estimate is 19 percentage points below it, and the stated range covers the measured number.
By their numbers in this assay, from the lowest: compounds 3, 4 and 2 (each within the scatter of the next, the first and the last beyond it); then compound 1.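

In this assay, placing a saturated chain carbon between the aromatic nitrogen and the phenyl ring gives a number 8 percentage points higher from compound 3 to compound 4 (within the scatter), whereas the same kind of change on the cyclohexyl ring gave a number 15 percentage points lower from compound 1 to compound 2 (beyond the scatter), so the effect of this insertion at this position is not the same for the two rings. With that chain carbon present, the identity of the ring no longer stands out from the scatter, as phenyl in place of cyclohexyl gives a number 3 percentage points lower from compound 2 to compound 4 (within the scatter), while the same swap directly on the aromatic nitrogen gave a number 26 percentage points lower from compound 1 to compound 3 (beyond the scatter). Cyclohexyl directly on the nitrogen also remains apart from the benzyl group, with a number 18 percentage points lower from compound 1 to compound 4 (beyond the scatter), which shows that a ring on a chain carbon does not match the response of the directly attached cyclohexyl.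

Nothing available explains why the two rings respond differently to the added carbon. Going by these compounds, it also remains open whether a longer chain, such as phenethyl or cyclohexylethyl, would leave the response unchanged or shift it, and whether an amine or a carboxylic acid on the benzyl ring would do so.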